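Shifting the ring nitrogen in a trimethoxyphenyl enone

The source may hold more compounds than are shown below. What is called first, only, known or untested is meant among the compounds shown, and "the series" means these compounds.

Of the compounds shown here, three have been measured in a functional assay with Rattus norvegicus as the target; a higher number here means a weaker inhibitor, a lower number a stronger inhibitor. Compound 1, `O=C(/C=C/c1ccncc1)c1cccc(C(F)(F)F)c1`, gives 41000 nM, and compound 2, `O=C(/C=C/c1ccncc1)c1ccc(Cl)cc1`, gives 60000 nM. Compound 3, `COc1cc(C(=O)/C=C/c2ccncc2)cc(OC)c1OC`, gives 7000 nM, the lowest of the three numbers; its gap to compound 1 and its larger gap to compound 2 both lie beyond the usual scatter of repeated measurements, so compound 3 is the strongest inhibitor among the three.

Compound 4, `COc1cc(C(=O)/C=C/c2cccnc2)cc(OC)c1OC`, keeps the same atoms as compound 3 but joins them differently: pyridin-3-yl in place of pyridin-4-yl on a double-bonded chain carbon bound to a double-bonded chain carbon. The ring nitrogen is thus moved within the ring, while the trimethoxy-substituted part of the molecule is unchanged. Going by the values given here, no measured pair shows this particular change, so its effect can only be guessed from how the three values spread across the unrelated changes on the other ring.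

For compound 4 a small weakening is expected, close to the scatter, so that the number is estimated at 12000 nM, with a range from 3500 nM to 45000 nM. The step expected from compound 3 to compound 4, a 1.7-fold higher number from compound 3 to compound 4 (0.23 log units; within the scatter), is a modest rise rather than a loss of the advantage compound 3 holds over compounds 1 and 2.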

Compound 4, half-maximal inhibitory concentration: 30000 nM
Compound 4: middle estimate off by 2.5-fold (0.40 log units), on the low side, and the stated range covers the measured number.
By their numbers in this assay, from the lowest: compound 3; then compounds 4, 1 and 2 (each within the scatter of the next).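

In this assay, the swap of pyridin-3-yl for pyridin-4-yl on a double-bonded chain carbon bound to a double-bonded chain carbon gives a 4.3-fold higher number from compound 3 to compound 4 (0.63 log units; beyond the scatter) and so a weaker inhibitor, a step that lies beyond the usual scatter of repeated measurements. Going by these compounds alone, this is the first step here between two compounds that differ in one place, and it shows that this position responds to where the nitrogen sits in the ring, even though the two groups match in heavy atoms, hydrogen-bond donors, hydrogen-bond acceptors and net charge. No measurement shown here explains why the nitrogen's location matters, so the step stands as an observation without a known cause.

On these data alone, it remains open how pyridin-2-yl, or a phenyl group with no ring nitrogen at all, would behave at this position, so a single step cannot yet show whether the ring nitrogen itself is needed. As far as these compounds go, it is equally open whether the same shift of the nitrogen would give a step of similar size in compound 1 or compound 2, which carry different groups on the other ring.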